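Series notes: aryl-methyl replacement at the chain amine

The source may report more compounds than this note shows. Statements on the series, on what has been measured and on what is new or still open speak of the compounds shown alone.

Across the series, compound 2 `c1ccc2c(c1)CN[C@@H](CN(CCCCNCC1CCNCC1)[C@H]1CCCc3cccnc31)C2` stands second highest of the three numbers in a functional assay on cells for antagonist activity at C-X-C chemokine receptor type 4 (Homo sapiens), read by fluorescence and calcium flux, with stated times of 25 min and 90 s (on this read-out higher numbers stand for weaker inhibition and lower numbers for stronger inhibition), where compound 2 gives 36.5 nM. Its nearest neighbour is compound 3 `O=S1(=O)CCC(NCCCCN(C[C@H]2Cc3ccccc3CN2)[C@H]2CCCc3cccnc32)CC1`, which in this assay gives 45.5 nM; the step of a 1.2-fold higher number from compound 2 to compound 3 (0.10 log units; within the scatter) lies within the scatter. Compound 1 `c1cncc(CNCCCCN(C[C@H]2Cc3ccccc3CN2)[C@H]2CCCc3cccnc32)c1` gives 15.3 nM in this assay, and the step of a 2.4-fold higher number from compound 1 to compound 2 (0.38 log units; beyond the scatter) is modest but beyond the scatter.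

Compound 4 `NCc1ccccc1CN(C[C@H]1Cc2ccccc2CN1)[C@H]1CCCc2cccnc21` is not yet measured. It differs from compound 2 by a group of 8 heavy atoms (7 carbon, 1 nitrogen; one six-membered aromatic ring of carbon only) in place of a group of 11 heavy atoms (9 carbon, 2 nitrogen; one six-membered non-aromatic ring with 1 hetero atom), on a saturated chain carbon bound to an amine nitrogen. Among the compounds with values here, no measured step matches this change exactly. Within the data shown here, the only step at the same place is a 2.4-fold higher number from compound 1 to compound 2 (0.38 log units; beyond the scatter), where a six-membered aromatic ring was exchanged for a saturated ring and the number rose modestly; the step of a 1.2-fold higher number from compound 2 to compound 3 (0.10 log units; within the scatter) at the amine nitrogen was within the scatter. Reversing the direction of the first of these, a modest lowering of the number is expected, partly offset by the lack of any direct precedent for the entering group. The step of a 1.7-fold lower number from compound 2 to compound 4 (0.22 log units; within the scatter) is therefore expected to be small and downward, close to the edge of the scatter. Compound 4 is estimated at 22 nM in this assay, with a range from 7 nM to 70 nM.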

Compound 4, half-maximal inhibitory concentration: 50.8 nM
Compound 4: the middle estimate sits 2.3-fold (0.36 log units) below what was measured; the range from low to high includes it.
By their numbers in this assay, from the lowest: compound 1; then compounds 2, 3 and 4 (each within the scatter of the next).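

In this assay, the change to 2-(aminomethyl)phenyl on a saturated chain carbon bound to an amine nitrogen gives a 1.4-fold higher number from compound 2 to compound 4 (0.14 log units; within the scatter), so this position accepts a much shorter group with a six-membered aromatic ring of carbon only, in place of the larger group with a non-aromatic ring, with no readable change in the number. The aromatic ring alone does not recover the number of compound 1, which stays apart at a 3.3-fold higher number from compound 1 to compound 4 (0.52 log units; beyond the scatter); the earlier step from compound 1 to compound 2 therefore cannot be read as a general preference for an aromatic ring at this place, and compounds 2, 3 and 4 now form a group, each within the scatter of the next. The data shown offer no measured basis for explaining this result.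

The compounds shown do not separate the contribution of the pyridin-3-yl ring of compound 1 from that of the amine that carries it. A 3-aminopropyl group at this place, which holds the chain amine with no ring, and a pyridin-3-yl group set directly on the same carbon would bear on that question.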